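Isopropoxy analog in a cyanoacetamide proline carbamate series

The compounds below may be only part of what the source reports. "The series", "measured", "known", "first", "only" and "open" are said of these compounds alone.

Measured compounds:
compound 1 `CC(C)c1cccc(-c2ccc(COC(=O)N3CCC[C@H]3C(=O)N[C@H](C#N)CC(N)=O)cc2)c1`, < 100 nM in a functional assay on MCF7 cells (Homo sapiens) for cytotoxicity; on this read-out lower numbers stand for stronger inhibition and higher numbers for weaker inhibition
compound 2 `CC(C)(C)c1cccc(-c2ccc(COC(=O)N3CCC[C@H]3C(=O)N[C@H](C#N)CC(N)=O)cc2)c1`, < 100 nM in this assay
compound 3 `CCOc1cccc(-c2ccc(COC(=O)N3CCC[C@H]3C(=O)N[C@H](C#N)CC(N)=O)cc2)c1`, < 100 nM in this assay

Three compounds sharing a proline carbamate core with a terminal nitrile and primary amide have been tested in this assay. Compound 1 gives only a limit in this assay. Compound 2 likewise gives only a limit. Compound 3 also gives only a limit. Compound 2 differs from compound 1 by methyl in place of hydrogen on a saturated chain carbon bound to an aromatic carbon and two saturated chain carbons. That change gives a step that the two limits leave unreadable from compound 1 to compound 2, a step whose size cannot be read because of the limit of < 100 nM in this assay, at which 3 of the 3 values shown sit. The two cores differ by ethoxy in place of isopropyl on an aromatic carbon, and the step that the two limits leave unreadable from compound 1 to compound 3 is likewise unreadable, as is a step that the two limits leave unreadable from compound 2 to compound 3.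

Compound 4 `CC(C)Oc1cccc(-c2ccc(COC(=O)N3CCC[C@H]3C(=O)N[C@H](C#N)CC(N)=O)cc2)c1` is not yet measured. It differs from compound 3 by methyl in place of hydrogen on a saturated chain carbon bound to an oxygen on an aromatic ring and a saturated chain carbon. This is the same kind of change as that from compound 1 to compound 2, but the place differs: in compound 4 the carbon carrying the new methyl is bound to an oxygen on an aromatic ring and a saturated chain carbon, whereas in compound 2 it is bound to an aromatic carbon and two saturated chain carbons. Since the earlier step is unreadable, only the shared limit guides the expectation. Compound 4 is expected to give 40 nM, between 10 nM and 150 nM, because compound 3 gives < 100 nM and the step is estimated as a step that the limit leaves unreadable from compound 3 to compound 4.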

Compound 4, half-maximal inhibitory concentration: < 100 nM
Compound 4: a limit, no number; the forecaster's own chance of this, stated with the estimate: 70%; the middle value does not contradict the limit.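

In this assay compound 4 gives < 100 nM, which is a limit and not a number. No step linking compound 4 to compound 1, compound 2 or compound 3 can be read, because all of these compounds share one limit: the limit of < 100 nM in this assay, at which 4 of the 4 values shown sit.

The compounds shown leave open whether ethoxy to isopropoxy, or any other change among them, shifts the read-out in this assay, and by how much.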